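A Methoxy Swap on an Inactive Sulfonamide Pair

The source may hold more compounds than are shown below. What is called first, only, known or untested is meant among the compounds shown, and "the series" means these compounds.

Compound 1 `Cc1ccc(S(=O)(=O)Nc2ccc(-c3nc4ccccc4o3)cc2)cc1` and compound 2 `C=Cc1ccc(S(=O)(=O)Nc2ccc(-c3nc4ccccc4o3)cc2)cc1` share one core and differ only in a single group on an aromatic carbon. In an assay on cells for inhibition of HSP60/HSP10 (Homo sapiens), with a stated time of 60 min (a higher number here means a weaker inhibitor, a lower number a stronger inhibitor), compound 1 gives > 100000 nM, which is a limit of the assay and not a number. In this assay compound 2 gives > 100000 nM, again a limit rather than a number. The step that the two limits leave unreadable from compound 1 to compound 2 therefore cannot be read in size. Compound 2 thus stands at the limit of > 100000 nM in this assay, at which 2 of the 2 values shown sit, where both values shown sit.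

Compound 3 `COc1ccc(S(=O)(=O)Nc2ccc(-c3nc4ccccc4o3)cc2)cc1` differs from compound 2 by methoxy in place of vinyl on an aromatic carbon. Going by the values given here, only the step from compound 1 to compound 2 bears on this change, and its size is not readable, since both of its ends are limits. Among the compounds with values here, no measured step shows any swap of this group lifting the value off the limit. For compound 3, the estimated step of a number no higher from compound 2 to compound 3 (the limit leaves the size open) is expected to be none beyond the scatter. Compound 3 is therefore expected to give about 100000 nM in this assay, with a range from 30000 nM to 300000 nM, and most likely only a limit once more.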

Compound 3, half-maximal inhibitory concentration: > 100000 nM
Compound 3: only a limit was reported; the forecaster's own chance of this, stated with the estimate: 80%; the middle value lies on the limit itself.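

In this assay compound 3 gives > 100000 nM, a limit of the assay and not a number. The steps joining compound 1, compound 2 and compound 3 therefore cannot be read in size. The compounds shown leave open whether any group at this place gives a readable value, and how methyl, vinyl and methoxy compare: the limit of > 100000 nM in this assay, at which 3 of the 3 values shown sit.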